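The source may hold more compounds than are shown below. What is called first, only, known or untested is meant among the compounds shown, and "the series" means these compounds.

Values in an ADME assay on HepG2 cells (Homo sapiens) for cytotoxicity, read by luminescence, CellTiter-Glo and ATP content, with a stated time of 72 h; on this read-out higher numbers stand for an effect only at larger amounts of compound and lower numbers for an effect already at smaller amounts:
compound 1 `c1ccc(-c2ccc3c(NCCCNCc4ccco4)ccnc3c2)cc1`: 5920 nM
compound 2 `Fc1ccc(Cc2ccc3c(NCCCNCc4ccco4)ccnc3c2)cc1`: 5600 nM
compound 3 `c1ccc(Cc2ccc3c(NCCCNCc4ccco4)ccnc3c2)cc1`: 16000 nM

Compound 3 stands highest of the three numbers. The step of a 2.7-fold higher number from compound 1 to compound 3 (0.43 log units; beyond the scatter) and the step of a 2.9-fold higher number from compound 2 to compound 3 (0.46 log units; beyond the scatter) are both beyond the scatter, whereas a 1.1-fold lower number from compound 1 to compound 2 (0.02 log units; within the scatter) lies within it, so the three measured compounds span only a modest range in this assay.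

Compound 4 `CN(C)c1cccc(Oc2ccc3c(NCCCNCc4ccco4)ccnc3c2)c1` differs from compound 3 by 3-(dimethylamino)phenoxy in place of benzyl on an aromatic carbon. Within the data shown here, the two steps that bear on a change at this position are the ones ending at compound 3, each of modest size; neither involves the entering group, so no measured pair shows what a 3-(dimethylamino)phenoxy group does here. Given that every change at this position so far has moved the number only modestly, a modest step back toward the values of compound 1 and compound 2 is expected, that is a 2.0-fold lower number from compound 3 to compound 4 (0.30 log units; within the scatter). For compound 4 the estimate is 8000 nM, with a range from 2500 nM to 25000 nM, the width reflecting the absence of any precedent for the entering group.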

Compound 4, half-maximal effective concentration: 16000 nM
Beside the measured number, compound 4's estimate is 2.0-fold (0.30 log units) below it; the measured number falls inside the stated range.
By their numbers in this assay, from the lowest: compounds 2 and 1 (each within the scatter of the next); then compounds 3 and 4 (each within the scatter of the next).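

In this assay, 3-(dimethylamino)phenoxy and benzyl cannot be told apart at this position, with no change at the digits printed from compound 3 to compound 4 (within the scatter), even though the entering group is larger and brings hydrogen-bond acceptors that benzyl lacks. The split among the measured compounds therefore holds for a second, quite different group: a 2.9-fold higher number from compound 2 to compound 4 (0.46 log units; beyond the scatter) and a 2.7-fold higher number from compound 1 to compound 4 (0.43 log units; beyond the scatter), so compounds 3 and 4 form one level and compounds 1 and 2 the other. Nothing at hand accounts for this split.

As far as these compounds go, a plain phenoxy group would separate the contribution of the oxygen link from that of the dimethylamino group, and that comparison remains open. Also open, from the compounds shown here alone, is whether a carboxylic acid or a primary amine at this position would leave the number at either level.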